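The source may hold more compounds than are shown below. What is called first, only, known or untested is meant among the compounds shown, and "the series" means these compounds.

Notes on the efficacy series around compound 2 `C[C@H](C(=O)Nc1nccs1)c1ccc(Cl)cc1`. Among the compounds with values here, in a functional assay on CHO cells for agonist activity at Free fatty acid receptor 2 (Homo sapiens), read by cAMP accumulation (a higher number here means a larger maximal response, a lower number a smaller maximal response), compound 2 gives 83%, the only full number in the set. Compound 1 `CC(C)C(C(=O)Nc1nc(-c2cccnc2)cs1)c1ccc(Cl)cc1` returns a limit of the assay in this assay, < 30%, the point (the limit of < 30% in this assay, at which 1 of the 2 values shown sits). Within the data shown here, compound 1 also carries an isopropyl on the chain carbon but differs from compound 3 elsewhere as well, so its value shows no isolated step. Compound 3 `CC(C)C[C@H](C(=O)Nc1nccs1)c1ccc(Cl)cc1` differs from compound 2 by isopropyl in place of hydrogen on a saturated chain carbon, two bonds along the chain from an aromatic carbon and a carbonyl carbon. A step beyond the scatter toward smaller maximal response is expected, a number 38 percentage points lower from compound 2 to compound 3 (beyond the scatter). Compound 3 is estimated at 45%, range 20% to 75%, with a fair chance of only a limit.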

Compound 3, largest response reached (reported as efficacy), in percent of the reference or control that the assay uses: 68%
Beside the measured number, compound 3's estimate is 23 percentage points below it; low and high end bracket the measured number.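

In this assay, the change from methyl to isobutyl on this saturated chain carbon gives a number 15 percentage points lower from compound 2 to compound 3 (beyond the scatter), a modest loss of maximal response. Within the data shown here, this is the first single-place reading at this position, and it shows that a branched alkyl group here still leaves a full number rather than a limit. Nothing measured here bears on why the step arises.

Among these compounds, with only one change read at this place, no trend with chain size can be drawn. On these data alone, how a longer chain, an amine or a carboxylic acid on this carbon would behave remains open.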